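From isopropylamino to cyclopropylamino: one small swap

The source may hold more compounds than are shown below. What is called first, only, known or untested is meant among the compounds shown, and "the series" means these compounds.

Compound 1 `COc1ncnc2c1ncn2C[C@@H]1C[C@H](CO)c2ccccc21`: 24 ug/mL
Compound 2 `CC(C)Nc1ncnc2c1ncn2C[C@@H]1C[C@H](CO)c2ccccc21`: 24 ug/mL
Compound 3 `OC[C@H]1C[C@@H](Cn2cnc3c(NC4CC4)ncnc32)c2ccccc21`: not yet measured

In a functional assay on CCRF-CEM cells (Homo sapiens) (on this read-out lower numbers stand for stronger inhibition and higher numbers for weaker inhibition), compound 2 gives 24 ug/mL, level with compound 1 at 24 ug/mL. The next move leads to compound 3: cyclopropyl in place of isopropyl on a nitrogen on an aromatic ring. In words, cyclopropyl takes the place of isopropyl on a nitrogen on an aromatic ring. For the measured compounds named here, only one measured step bears on this, no change at the digits printed from compound 1 to compound 2 (within the scatter), where isopropylamino replaced methoxy on an aromatic carbon. That single step is thin evidence, but it shows no movement, so no step beyond the scatter is expected in this assay. The expected size is no change at the digits printed from compound 2 to compound 3 (within the scatter). The estimated value for compound 3 is 24 ug/mL, with an expected range of 11 ug/mL to 50 ug/mL.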

Compound 3, half-maximal inhibitory concentration: 24 ug/mL
The estimate for compound 3 equals the measured number at the digits printed; the range from low to high includes it.
By their numbers in this assay, from the lowest: compounds 1, 2 and 3 (each within the scatter of the next).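

In this assay, the step of no change at the digits printed from compound 2 to compound 3 (within the scatter) shows that a three-membered ring of carbon on this nitrogen leaves the read-out where the open isopropyl group had it. The step of no change at the digits printed from compound 1 to compound 3 (within the scatter) adds a second amino group that sits level with methoxy on the aromatic carbon, so three different groups at this place now share one value. Nothing measured here explains why the value stays the same.

On these data alone, whether a longer chain such as n-butyl on the nitrogen would shift the value remains open. So does the effect of a carboxylic acid on that aromatic carbon.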